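A few compounds are considered here, and "the series" means these few. Any claim that something is new, unique, unknown or untested is made for them only; others in the source may bear on it.

In a functional assay on HCT-116 cells (Homo sapiens) for cytotoxicity (on this read-out higher numbers stand for weaker inhibition and lower numbers for stronger inhibition), compound 1 `O=C1NC(=O)c2c1c1c3ccccc3ccc1c1c2c2ccccc2n1[C@@H]1O[C@H](CO)[C@@H](O)[C@H](O)[C@H]1O` gives 5100 nM, and compound 2 `O=C1NC(=O)c2c1c1c3ccccc3ccc1c1c2c2ccccc2n1[C@@H]1O[C@H](CO)[C@@H](O)[C@H]1O` gives 3800 nM. Going by the values given here, the only measured step, a 1.3-fold lower number from compound 1 to compound 2 (0.13 log units; within the scatter), lies within the scatter, so compound 2 holds the lower of the two numbers without being set apart from compound 1. Compound 3 `O=C1NC(=O)c2c1c1c3ccccc3ccc1c1c2c2ccccc2n1[C@H]1C[C@H](O)[C@@H](CO)O1` differs from compound 2 by hydrogen in place of hydroxy on a saturated ring carbon. The step that bears on this change, a 1.3-fold lower number from compound 1 to compound 2 (0.13 log units; within the scatter), also removed a hydroxy from the sugar and stayed within the scatter; the expectation here is likewise a 1.3-fold lower number from compound 2 to compound 3 (0.10 log units; within the scatter), no move beyond the scatter. Compound 3 is therefore estimated at 3000 nM, between 1200 nM and 8000 nM.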

Compound 3, half-maximal inhibitory concentration: 8700 nM
Estimate against measurement, compound 3: 2.9-fold (0.46 log units) below; the whole stated range lies below it.
By their numbers in this assay, from the lowest: compounds 2, 1 and 3 (each within the scatter of the next, the first and the last beyond it).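

Taking the hydroxy off this saturated ring carbon is not neutral in this assay: hydrogen in its place gives a 2.3-fold higher number from compound 2 to compound 3 (0.36 log units; beyond the scatter), the only step among these compounds that passes the scatter, so losing a hydroxy from the sugar does not always leave the number in place. Measured against the sugar of compound 1, the same compound shows a 1.7-fold higher number from compound 1 to compound 3 (0.23 log units; within the scatter), so the two differ by no more than the scatter. Nothing available explains the step. Going by these compounds, it remains open whether an amine or a methoxy group on this carbon would stay with compound 2 or go with compound 3.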